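Shortening an Amine Chain in a Receptor Binding Series

The compounds below may be only part of what the source reports. "The series", "measured", "known", "first", "only" and "open" are said of these compounds alone.

Four close relatives share one core, and three of them have been tested in an assay on cells for displacement of a labelled ligand from corticotropin-releasing factor receptor 1 (Homo sapiens), with a stated time of 100 min; on this read-out lower numbers stand for stronger inhibition and higher numbers for weaker inhibition. Compound 1 `CCCCN(CC)Cc1c(C(F)(F)F)nc2n(-c3c(C)cc(C)cc3C)c(Cl)cn12` gives 78 nM in this assay. Compound 2 `CCCCN(C)Cc1c(C(F)(F)F)nc2n(-c3c(C)cc(C)cc3C)c(Cl)cn12` gives 310 nM, and compound 3 `CCCN(Cc1ccccc1)Cc1c(C(F)(F)F)nc2n(-c3c(C)cc(C)cc3C)c(Cl)cn12` gives 170 nM. Compound 4 `CCN(Cc1ccccc1)Cc1c(C(F)(F)F)nc2n(-c3c(C)cc(C)cc3C)c(Cl)cn12` has not yet been tested.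

The change from compound 1 to compound 2 is hydrogen in place of methyl on a saturated chain carbon bound to an amine nitrogen; in this assay it made a 4.0-fold higher number from compound 1 to compound 2 (0.60 log units; beyond the scatter). The cores of compound 1 and compound 3 differ by benzyl(propyl)amino in place of butyl(ethyl)amino on a saturated chain carbon bound to an aromatic carbon, which gave a 2.2-fold higher number from compound 1 to compound 3 (0.34 log units; beyond the scatter). Compound 2 and compound 3 lie within the scatter of each other, as a 1.8-fold lower number from compound 2 to compound 3 (0.26 log units; within the scatter) shows.

Compound 4 differs from compound 3 by hydrogen in place of methyl on a saturated chain carbon, two bonds along the chain from an amine nitrogen. For the measured compounds named here, this is the same kind of change as the one from compound 1 to compound 2, but the place is not identical: there the carbon is bound to an amine nitrogen, here it is two bonds along the chain from an amine nitrogen. Because the earlier step was a 4.0-fold higher number from compound 1 to compound 2 (0.60 log units; beyond the scatter) and the carbon here is two bonds along the chain from the amine nitrogen rather than bound to it, a smaller weakening is expected, around a 1.8-fold higher number from compound 3 to compound 4 (0.25 log units; within the scatter). Compound 4 is therefore estimated at 300 nM, expected to fall between 130 nM and 700 nM.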

Compound 4, inhibition constant: 350 nM
For compound 4 the middle estimate is 1.2-fold (0.07 log units) below the measured one, and the stated range covers the measured number.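

Shortening a chain by one carbon raised the number on both cores in this assay, here by a 2.1-fold higher number from compound 3 to compound 4 (0.31 log units; beyond the scatter), and the two steps do not differ beyond what repeated measurement would give: the same change on two cores in this assay, a 4.0-fold higher number (0.60 log units; beyond the scatter) from compound 1 to compound 2 and a 2.1-fold higher number (0.31 log units; beyond the scatter) from compound 3 to compound 4, 1.9-fold (0.29 log units) apart, within the scatter of two such steps This supports carrying the direction of the change from one core to the other, but it rests on only two pairs, and the chains differ, ethyl to methyl in one pair and propyl to ethyl in the other, so it does not establish a fixed size for the step or a rule for the whole series. The remaining steps alter the amine more broadly, with a 4.5-fold higher number from compound 1 to compound 4 (0.65 log units; beyond the scatter) and a 1.1-fold higher number from compound 2 to compound 4 (0.05 log units; within the scatter), so neither isolates the effect of removing one carbon.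

The compounds shown leave open how a longer chain such as pentyl, or a cyclopropylmethyl group on the amine nitrogen, would read on this core. They also leave open whether shortening the butyl chain of compound 1 would follow the same direction.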